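Trimming the propyl chain from compound 2 to compound 3

The compounds below may be only part of what the source reports. "The series", "measured", "known", "first", "only" and "open" are said of these compounds alone.

Compound 1 (`COc1ccc(/C=C2\CNC/C(=C\c3ccc(OC)c(OC)c3)C2=O)cc1OC`) gives 10300 nM
Compound 2 (`CCCN1C/C(=C\c2ccc(OC)c(OC)c2)C(=O)/C(=C/c2ccc(OC)c(OC)c2)C1`) gives 11200 nM

In a functional assay on NCI-H1975 cells (Homo sapiens) for cytotoxicity, read by MTT assay, with a stated time of 72 h (a higher number here means a weaker inhibitor, a lower number a stronger inhibitor), compound 2 stands at 11200 nM, within the scatter of compound 1 at 10300 nM. Compound 3 (`COc1ccc(/C=C2\CN(C)C/C(=C\c3ccc(OC)c(OC)c3)C2=O)cc1OC`) keeps the shared core but carries methyl where compound 2 carries propyl: hydrogen in place of ethyl on a saturated chain carbon bound to an amine nitrogen in a ring. Within the data shown here, one measured step bears on this change: a 1.1-fold higher number from compound 1 to compound 2 (0.04 log units; within the scatter), with propyl in place of hydrogen on that amine nitrogen. That step stayed within the scatter, and methyl is a shorter chain than propyl, so no step beyond the scatter is expected in this assay. The expected step is a 1.1-fold lower number from compound 2 to compound 3 (0.03 log units; within the scatter). For compound 3 the estimated value is 10500 nM, with an expected range from 5500 nM to 20000 nM.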

Compound 3, half-maximal inhibitory concentration: 6600 nM
Compound 3: the middle estimate sits 1.6-fold (0.20 log units) above what was measured; the measured number falls inside the stated range.
By their numbers in this assay, from the lowest: compounds 3, 1 and 2 (each within the scatter of the next).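

Read in this assay, the change from propyl to methyl on the amine nitrogen in a ring gives a 1.7-fold lower number from compound 2 to compound 3 (0.23 log units; within the scatter) and methyl in place of hydrogen there gives a 1.6-fold lower number from compound 1 to compound 3 (0.19 log units; within the scatter) as its companion step. The earlier compounds shown here compared only hydrogen with propyl at this position, whereas these steps add methyl and leave all three compounds within the scatter of one another, so no dependence on chain length can be read across these substituents. Nothing measured here accounts for these numbers.

The compounds shown leave open whether a longer chain, a benzyl group or a chain ending in a carboxylic acid on that nitrogen would move the number beyond the scatter. They also leave open whether these three compounds would stay so close in any other assay.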